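The compounds below may be only part of what the source reports. "The series", "measured", "known", "first", "only" and "open" are said of these compounds alone.

Measured compounds:
- compound 1 `CCC(=O)Nc1ncc(-c2ccc(OC)cc2)n1C`; in a toxicity assay on THP-1 cells (Homo sapiens) for inhibition (on this read-out higher numbers stand for lower toxicity in this test and lower numbers for higher toxicity in this test), compound 1 gives > 100000 nM, a limit of the test rather than a number.
- compound 2 `CCCn1c(-c2ccc(OC)cc2)cnc1NC(=O)c1ccc(F)cc1`; in this assay compound 2 gives > 100000 nM, again a limit.
- compound 3 `Cn1c(-c2ccccc2)cnc1NC(=O)c1ccccc1`; in this assay compound 3 gives > 100000 nM, also a limit.

Going by the values given here, compound 1 therefore stands where every value so far stands: at the limit of > 100000 nM in this assay, at which 3 of the 3 values shown sit. Among the compounds with values here, no measured pair of compounds differs in only one place, so no single step can be read from these numbers; all that the values of compounds 2 and 3 show is that they, too, sit at that limit.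

The next compound is compound 4 `COc1ccc(-c2cnc(NC(=O)c3cccc(Cl)c3)n2C)cc1`. Within the data shown here, its only difference from compound 1 is 3-chlorophenyl in place of ethyl on a carbonyl carbon. Compounds 2 and 3 carry an aromatic ring on the carbonyl carbon as well and remain at the limit, so no step beyond the usual scatter is expected from compound 1 to compound 4, a change estimated at a number no higher from compound 1 to compound 4 (the limit leaves the size open). For compound 4 the expected value in this assay is 100000 nM, with an estimated range from 50000 nM to 200000 nM, most likely again reported only as a limit.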

Compound 4, half-maximal cytotoxic concentration: > 28000 nM
Compound 4 gave a limit, no number; the forecaster's own chance of this, stated with the estimate: 80%; the middle value is on the limit's open side.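

In this assay compound 4 gives > 28000 nM, a limit and not a number. Going by these compounds alone, compound 1 also sits at a limit, so no step between compound 1 and compound 4 can be read. The compounds shown leave open whether 3-chlorophenyl in place of ethyl on a carbonyl carbon changes toxicity in this assay at all.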